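Cyclohexyl to methoxymethyl on the amide side chain

A few compounds are considered here, and "the series" means these few. Any claim that something is new, unique, unknown or untested is made for them only; others in the source may bear on it.

The series shares the core of compound 1 `COc1cccc(OC)c1C(=O)Nc1c[nH]nc1C(=O)N[C@H]1CC[C@H](OC)CC1` and is followed in an ADME assay on MRC5 cells (Homo sapiens) for inhibition, with a stated time of 72 h; on this read-out lower numbers stand for an effect already at smaller amounts and higher numbers for an effect only at larger amounts of compound. Compound 1 gives 31000 nM. Compound 2 `COc1cccc(OC)c1C(=O)Nc1c[nH]nc1C(=O)N[C@H]1CC[C@H](O)CC1` gives 34000 nM, and the step of a 1.1-fold higher number from compound 1 to compound 2 (0.04 log units; within the scatter) stays within the scatter. Compound 3 `COc1cccc(OC)c1C(=O)Nc1c[nH]nc1C(=O)NCC1CCCCC1` gives only > 50000 nM, which is a limit of this assay and not a number; it is the limit of > 50000 nM in this assay, at which 1 of the 3 values shown sits. Compound 3 therefore stands nowhere exactly on the numbers shown, only at or beyond that floor, with an at least 1.6-fold higher number from compound 1 to compound 3 (0.20 log units; that floor lies within the scatter) and an at least 1.4-fold higher number from compound 2 to compound 3 (0.16 log units; that floor lies within the scatter), both floors within the scatter.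

Compound 4 `COCCNC(=O)c1n[nH]cc1NC(=O)c1c(OC)cccc1OC` differs from compound 3 by methoxymethyl in place of cyclohexyl on a saturated chain carbon bound to an amide-type nitrogen. Among the measured compounds shown here, no measured step removes the ring itself; the two steps into compound 3 change only what sits on the ring and the spacing to the amide-type nitrogen, and neither moved beyond the scatter. They give no basis for expecting compound 4 to come back under the limit, and none for a further move outward. The step that the limit leaves unreadable from compound 3 to compound 4 is therefore expected to stay within the scatter. Compound 4 is estimated at 55000 nM, in the range 25000 nM to 120000 nM, and is more likely than not to be reported again as a limit.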

Compound 4, half-maximal effective concentration: > 50000 nM
Compound 4: a limit, no number (the forecaster's own chance of this, stated with the estimate: 65%); the middle value is on the limit's open side.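

In this assay compound 4, like compound 3, is reported only as a limit and not as a number: the limit of > 50000 nM in this assay, at which 2 of the 4 values shown sit.

Among the compounds shown here, removing the cyclohexyl ring from the amide side chain therefore does not bring the series back to a readable number, which no earlier compound could show, and the step between these two limit compounds cannot be read. Against the compounds that keep a substituted ring, the result gives only floors, with an at least 1.4-fold higher number from compound 2 to compound 4 (0.16 log units; that floor lies within the scatter) and an at least 1.6-fold higher number from compound 1 to compound 4 (0.20 log units; that floor lies within the scatter), so 2-methoxyethyl is not shown to differ beyond the scatter from 4-hydroxycyclohexyl or 4-methoxycyclohexyl.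

As far as these compounds go, how far compound 3 and compound 4 lie past the limit remains open, as does whether any group on this amide-type nitrogen gives a number clearly apart from those of compound 1 and compound 2. An amine, a carboxylic acid or a longer chain in place of 2-methoxyethyl would put that question to the same position.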